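Lengthening the Chain on the Amine Nitrogen Once More

The source may hold more compounds than are shown below. What is called first, only, known or untested is meant among the compounds shown, and "the series" means these compounds.

In an ADME assay on liver (Mus musculus) for metabolic stability, read by LC-MS, using microsomes and NADPH (a lower number here means that less of the compound is left, a higher number that more of the compound is left), compound 1 `CCCN(Cc1ccc(OCCN2C(=O)CCC2=O)c(C)c1)C(CC(=O)O)c1ccc(Cl)cc1` gives 75% and compound 2 `Cc1cc(CN(C)C(CC(=O)O)c2ccc(Cl)cc2)ccc1OCCn1c(=O)ccn(C)c1=O` gives 68%. Compound 3 `CCN(Cc1ccc(OCCn2c(=O)ccn(C)c2=O)c(C)c1)C(CC(=O)O)c1ccc(Cl)cc1` gives 37%, the lowest of the three numbers and beyond the scatter of both others.

Compound 4 `CCCN(Cc1ccc(OCCn2c(=O)ccn(C)c2=O)c(C)c1)C(CC(=O)O)c1ccc(Cl)cc1` has not been measured yet. It differs from compound 3 in one place: methyl in place of hydrogen on a saturated chain carbon, two bonds along the chain from an amine nitrogen. Put simply, a methyl stands in place of a hydrogen on a saturated chain carbon, two bonds along the chain from an amine nitrogen, so ethyl becomes propyl.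

For the measured compounds named here, one measured step bears on this change: a number 31 percentage points lower from compound 2 to compound 3 (beyond the scatter). That large step also put methyl in place of hydrogen, but on a saturated chain carbon bound to an amine nitrogen, so the two changes are related and not identical. A single step suggests a direction but does not establish a rule. Going by the values given here, compound 1, at 75%, is not one simple change away from compound 3, so it supplies no step here.

In this assay a further, more moderate fall is therefore expected, and a change within the scatter remains possible. The expected step is a number 12 percentage points lower from compound 3 to compound 4 (beyond the scatter). For compound 4 the estimated value is 25%, with an expected range of 8% to 45%.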

Compound 4, percent of the compound remaining: 23%
Compound 4: the middle estimate sits 2 percentage points above what was measured; measured number inside the range.
By their numbers in this assay, from the lowest: compound 4; then compound 3; then compounds 2 and 1 (each within the scatter of the next).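

In this assay the change from ethyl to propyl gives a number 14 percentage points lower from compound 3 to compound 4 (beyond the scatter) and so the fall seen at the first lengthening of the chain on the amine nitrogen continues, this time in a modest step. Taken as a whole, the change from methyl to propyl amounts to a number 45 percentage points lower from compound 2 to compound 4 (beyond the scatter) and the number drops with each added carbon across these three compounds, which all carry the same six-membered aromatic ring group. Propyl does not bring a low number with every such group, however: compound 1 goes against the trend, since it also carries propyl, and replacing its five-membered non-aromatic ring group with the six-membered aromatic ring group gives a number 52 percentage points lower from compound 1 to compound 4 (beyond the scatter) and shows that the low number belongs to this pairing and not to propyl alone.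

As far as these compounds go, it remains open whether a longer chain such as butyl would lower the number further, and how methyl or ethyl on the amine nitrogen would read alongside the five-membered ring group of compound 1. Nothing at hand explains why any of these numbers fall.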